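Fluoro to methyl on the distal phenyl of the biaryl amine

This account rests on a few compounds, and the source may have more. Where it says the series, first, only, none or still open, it means among the compounds named here.

Working notes on a small biaryl series sharing one core. Compound 1 `CN(CC1=CC[C@H]2C[C@@H]1C2(C)C)Cc1ccc(-c2ccccc2)cc1` gives 3160 nM in an assay on HEK293 cells for displacement of a labelled ligand from C-X-C chemokine receptor type 3 (Homo sapiens); on this read-out lower numbers stand for stronger inhibition and higher numbers for weaker inhibition. Compound 2 `CN(CC1=CC[C@H]2C[C@@H]1C2(C)C)Cc1ccc(-c2cccc(F)c2)cc1` gives 2510 nM in this assay, and the step of a 1.3-fold lower number from compound 1 to compound 2 (0.10 log units; within the scatter) is within the scatter. Compound 3 `CN(CC1=CC[C@H]2C[C@@H]1C2(C)C)Cc1ccc(-c2ccccc2F)cc1` stands only at a limit in this assay, > 316 nM, so no number is known for it; the steps a step that the limit leaves unreadable from compound 1 to compound 3 and a step that the limit leaves unreadable from compound 2 to compound 3 therefore cannot be sized, and the only firm statement is that compound 3 sits at the limit of > 316 nM in this assay, at which 1 of the 3 values shown sits.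

The next compound, compound 4 `Cc1cccc(-c2ccc(CN(C)CC3=CC[C@H]4C[C@@H]3C4(C)C)cc2)c1`, carries 3-methylphenyl in place of 2-fluorophenyl on an aromatic carbon. For the measured compounds named here, no measured step swaps a fluorine for a methyl anywhere in the set, so the only relevant comparison is the fluoro step from compound 1 to compound 2, which was within the scatter, while both steps into compound 3 are unreadable. With compound 3 anchored only by its limit, the step from compound 3 to compound 4 cannot be read against a number, and compound 4 is expected to land near the values of compound 1 and compound 2 rather than far from them, with a step that the limit leaves unreadable from compound 3 to compound 4 taken as the estimated step. Compound 4 is thus estimated at 2500 nM in this assay, within a range from 800 nM to 8000 nM.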

Compound 4, inhibition constant: > 316 nM
Compound 4 ended at the assay's limit; the forecaster's own chance of this, stated with the estimate: 30%; the middle value is on the limit's open side.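

Compound 4 stands only at a limit in this assay, > 316 nM, so its steps from compound 1, compound 2 and compound 3 cannot be read; it now shares that position with compound 3: the limit of > 316 nM in this assay, at which 2 of the 4 values shown sit.

The compounds shown leave open whether 3-methylphenyl and 3-fluorophenyl differ at all in this assay, and where compound 3 and compound 4 truly lie.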